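A non-aromatic ring gives way to an aromatic one

The source may report more compounds than this note shows. Statements on the series, on what has been measured and on what is new or still open speak of the compounds shown alone.

Compound 1 `COc1c(/C=C/c2ccc(NS(C)(=O)=O)c(F)c2)cc(-n2ccc(=O)[nH]c2=O)cc1C(C)(C)C` and compound 2 `COc1c(/C=C/c2ccc(NS(C)(=O)=O)cc2)cc(N2CCC(=O)NC2=O)cc1C(C)(C)C` have both been measured in an ADME assay on the whole organism (strain Sprague-Dawley) for metabolic stability, with Rattus norvegicus as the target, at a dose of 5 mg/kg by the oral route (on this read-out lower numbers stand for a shorter-lived compound and higher numbers for a longer-lived compound), where compound 1 gives 3.7 h and compound 2 gives 2.3 h as two numbers within the usual scatter of each other. Compound 3 `COc1c(/C=C/c2ccc(NS(C)(=O)=O)cc2)cc(-n2ccc(=O)[nH]c2=O)cc1C(C)(C)C` has not yet been measured and differs from compound 2 in one place, with a group of 8 heavy atoms (4 carbon, 2 nitrogen, 2 oxygen; one six-membered aromatic ring with 2 hetero atoms) in place of a group of 8 heavy atoms (4 carbon, 2 nitrogen, 2 oxygen; one six-membered non-aromatic ring with 2 hetero atoms), on an aromatic carbon as the counted difference. A six-membered aromatic ring with 2 hetero atoms takes the place of a six-membered non-aromatic ring with 2 hetero atoms, on an aromatic carbon para to a methoxy group. Within the data shown here, no measured step shows what this exchange does in this assay so the evidence is thin. With compound 1 at 3.7 h and compound 2 at 2.3 h within the scatter of each other, no step beyond the scatter is expected in either direction. The estimated step of a 1.2-fold higher number from compound 2 to compound 3 (0.09 log units; within the scatter) stays within that scatter. Compound 3 is expected at 2.8 h with an estimated range from 1.5 h to 5.2 h in this assay.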

Compound 3, half-life in the Rattus norvegicus assay: 3.1 h
For compound 3 the middle estimate is 1.1-fold (0.04 log units) below the measured one; the range from low to high includes it.
By their numbers in the Rattus norvegicus assay, from the lowest: compounds 2, 3 and 1 (each within the scatter of the next).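

In the Rattus norvegicus assay compound 2 gives 2.3 h and compound 3 gives 3.1 h, so the exchange of the six-membered non-aromatic ring for the six-membered aromatic ring, on the aromatic carbon para to a methoxy group, now has a measured step of its own, a 1.3-fold higher number from compound 2 to compound 3 (0.13 log units; within the scatter), and the two rings are not told apart on half-life at this position. The fluoro group, which compounds differing in two places could not isolate, can now be read alone: hydrogen in its place on an aromatic carbon gives a 1.2-fold lower number from compound 1 to compound 3 (0.08 log units; within the scatter), also inside the scatter. In a physicochemical assay for solubility, at pH 7.2 (a higher number here means a more soluble compound, a lower number a less soluble compound), compound 2 gives 10300 nM and compound 3 gives 20700 nM, and the same ring exchange gives a 2.0-fold higher number from compound 2 to compound 3 (0.30 log units; within the scatter), so solubility does not separate the two rings either.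

As far as these compounds go, whether a carboxylic acid or an amine on this aromatic carbon would shift the half-life beyond the scatter stays open. Nothing shown accounts for these readings.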